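This account rests on a few compounds, and the source may have more. Where it says the series, first, only, none or still open, it means among the compounds named here.

Working notes on the series.

The shared core of compound 1 `Cc1nc2c(OCc3ccc(C(F)(F)F)cc3)cccn2c1N` carries an ether substituent on an aromatic ring; in a functional assay on the whole organism with Canis familiaris (Canis lupus familiaris) as the target, at a dose of 2 mg/kg by the intravenous route (on this read-out higher numbers stand for a stronger effect at the one dose given and lower numbers for a weaker effect), compound 1 gives 0%. Compound 2 `Cc1nc2c(OCc3cccs3)cccn2c1N`, bearing a (thiophen-2-yl)methyl ether, stands highest of the two measured numbers: in this assay compound 2 gives 77%, a gap to compound 1 that lies beyond the scatter. Compound 3 `Cc1nc2c(Oc3ccccc3)cccn2c1N` has not yet been measured. It differs from compound 2 in one place: phenyl in place of (thiophen-2-yl)methyl on an oxygen on an aromatic ring. Among the measured compounds shown here, no pair of measured compounds is separated by a single change, so nothing directly shows how this substitution acts; the two measured values show only that the ether substituent can move the read-out across most of the range. The step expected in this assay is a number 42 percentage points lower from compound 2 to compound 3 (beyond the scatter), a fall beyond the scatter. Compound 3 is estimated at 35%, with a range from 5% to 70%.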

Compound 3, a percentage reported as inhibition, in the whole organism at one dose (the size of the read-out at that dose, not a potency): 40%
Beside the measured number, compound 3's estimate is 5 percentage points below it; measured number inside the range.
By their numbers in this assay, from the lowest: compound 1; then compound 3; then compound 2.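

Among the compounds shown here, this is the first single change that can be read directly: phenyl in place of (thiophen-2-yl)methyl on an oxygen on an aromatic ring gives a number 37 percentage points lower from compound 2 to compound 3 (beyond the scatter) in this assay. The two groups have the same count of heavy atoms, so a large step can occur at this position without a change in that count, and compound 3 still gives 40%. No measurement available here bears on what lies behind this step.

The compounds shown leave open whether the step follows the change of ring, the loss of the methyl link between ring and oxygen, or both. An unsubstituted benzyl or a (furan-2-yl)methyl group on the same oxygen would help to separate these possibilities.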